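Phenyl to Methyl on a Ring Nitrogen: an Estimate

This account rests on a few compounds, and the source may have more. Where it says the series, first, only, none or still open, it means among the compounds named here.

compound 1 `Cc1nc2cc3c(cc2n1-c1ccccc1)C1CNCC3C1`: < 5 nM
compound 2 `CC(=O)c1ccc2c(c1)C1CNCC2C1`: 0.17 nM
compound 3 `N#Cc1ccc2c(c1)C1CNCC2C1`: 0.5 nM

All three were tested in an assay on HEK293 cells for binding affinity to Neuronal acetylcholine receptor; alpha4/beta2 (Homo sapiens); on this read-out lower numbers stand for stronger inhibition and higher numbers for weaker inhibition. For compound 1 the value < 5 nM is a limit of the assay, not a number, as the limit of < 5 nM in this assay, at which 1 of the 3 values shown sits, shows. Compound 2 and compound 3 have firm numbers. For the measured compounds named here, the one measured step, a 2.9-fold higher number from compound 2 to compound 3 (0.47 log units; beyond the scatter), concerns cyano in place of acetyl on an aromatic carbon, far from the change considered here.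

Compound 4 `Cc1nc2cc3c(cc2n1C)C1CNCC3C1` has not yet been measured. It differs from compound 1 by methyl in place of phenyl on an aromatic nitrogen. Going by the values given here, no measured step touches that aromatic nitrogen, so the measured data give no direction and no size for this change. Compound 4 is therefore expected to give about 2 nM, in a range from 0.3 nM to 15 nM, which corresponds to an expected step that the limit leaves unreadable from compound 1 to compound 4 that may well stay within the scatter.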

Compound 4, inhibition constant: 0.31 nM
Estimate against measurement, compound 4: 6.5-fold (0.81 log units) above; low and high end bracket the measured number.
By their numbers in this assay, from the lowest: compounds 2, 4 and 3 (each within the scatter of the next, the first and the last beyond it).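

No step from compound 1 to compound 4 can be read, because the value for compound 1 is a limit and not a number: the limit of < 5 nM in this assay, at which 1 of the 4 values shown sits.

The compounds shown leave open how far methyl in place of phenyl on the aromatic nitrogen shifts the number in this assay, and in which direction.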